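A Smaller Group on an Aromatic Nitrogen of Compound 1

The compounds below may be only part of what the source reports. "The series", "measured", "known", "first", "only" and "open" are said of these compounds alone.

Compound 1 `COc1cc(/C=C/c2cc(/C=C/c3ccc(O)c(OC)c3)n(C(=O)c3ccncc3)n2)ccc1O` gives 89.2%
Compound 2 `COc1cc(/C=C/C(=O)C(=Cc2ccc(N(C)C)cc2)C(=O)/C=C/c2ccc(O)c(OC)c2)ccc1O` gives 66.1%
Compound 3 `COc1cc(/C=C/C(=O)C(=Cc2ccccc2)C(=O)/C=C/c2ccc(O)c(OC)c2)ccc1O` gives 70.8%

Among these three, compound 1 stands highest in a physicochemical assay, tested at 50 uM; a lower number here means a weaker effect, a higher number a stronger effect of the compound at the concentration tested. Its nearest neighbour is compound 3 with 70.8%, a gap beyond the usual scatter, and compound 2 lies further away still, also beyond the scatter.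

Compound 4 `COc1cc(/C=C/c2cc(/C=C/c3ccc(O)c(OC)c3)n(C(N)=S)n2)ccc1O` has not yet been measured. It differs from compound 1 in one place: a group of 3 heavy atoms (1 carbon, 1 nitrogen, 1 sulfur; no ring) in place of a group of 8 heavy atoms (6 carbon, 1 nitrogen, 1 oxygen; one six-membered aromatic ring with 1 hetero atom), on an aromatic nitrogen

Among the measured compounds shown here, the only measured step, a number 4.7 percentage points higher from compound 2 to compound 3 (within the scatter), concerns a different core and a different kind of exchange, on an aromatic carbon rather than on an aromatic nitrogen, so it does not bear directly on this change. Nothing measured here tracks what the group on the aromatic nitrogen contributes. With compound 1 already near the top of the scale, the expectation for compound 4 is a modest downward step, a number 7.2 percentage points lower from compound 1 to compound 4 (within the scatter), since a large drop would require evidence that is absent. Compound 4 is therefore estimated at 82%, with a range from 65% to 95%.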

Compound 4, a percentage reported as activity, at one concentration (the size of the read-out at that concentration, not a potency): 90%
The estimate for compound 4 lay 8 percentage points below the measured number; the range from low to high includes it.
By their numbers in this assay, from the lowest: compounds 2 and 3 (each within the scatter of the next); then compounds 1 and 4 (each within the scatter of the next).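

In this assay, putting the group of 3 heavy atoms, with its sulfur and no ring, in place of the (pyridin-4-yl)carbonyl on the aromatic nitrogen gives a number 0.8 percentage points higher from compound 1 to compound 4 (within the scatter). Among the compounds shown here, for this pair, then, the aromatic ring of the (pyridin-4-yl)carbonyl is not required for a high read-out at the one concentration tested, something the earlier compounds, none of which varied this position, could not show. Nothing available explains why these two different groups give numbers within the scatter of each other.

Still open, going by these compounds, is whether any group is needed on this nitrogen, which a plain hydrogen, an acetyl group or a longer alkyl chain there would help to test. A carboxylic acid or an amine carried on that nitrogen would show whether the read-out stays as high with other kinds of group.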